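The compounds below may be only part of what the source reports. "The series", "measured", "known", "first", "only" and "open" are said of these compounds alone.

Measured compounds:
- Compound 1, `Cc1cccc(COc2ccc(-c3cc(CN4CCN(Cc5ccc(C(F)(F)F)cc5)CC4)no3)cc2)c1`: 5000 nM
- Compound 2, `Fc1cccc(COc2ccc(-c3cc(CN4CCN(Cc5ccc(C(F)(F)F)cc5)CC4)no3)cc2)c1`: 1300 nM
- Compound 3, `Cc1cc(-c2cc(CN3CCN(Cc4ccc(C(F)(F)F)cc4)CC3)no2)ccc1OCc1cccc(C#N)c1`: 600 nM

These three were tested in a functional assay on Huh-7 cells (Homo sapiens) for antiproliferative activity, read by sulforhodamine B assay, with a stated time of 72 h; on this read-out higher numbers stand for weaker inhibition and lower numbers for stronger inhibition. Compound 1 and compound 2 share one core and differ by fluoro in place of methyl on an aromatic carbon; that step gave a 3.8-fold lower number from compound 1 to compound 2 (0.59 log units; beyond the scatter). Compound 3 rests on a different core; the difference between the two cores is not broken down here. Among the three, compound 3 has the lowest number.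

Compound 4, `N#Cc1cccc(COc2ccc(-c3cc(CN4CCN(Cc5ccc(C(F)(F)F)cc5)CC4)no3)cc2F)c1`, has not yet been measured. It differs from compound 3 by fluoro in place of methyl on an aromatic carbon. This is the same kind of change as from compound 1 to compound 2, but not the same: here the place is ortho to a (3-cyanobenzyl)oxy group, whereas in the earlier pair it is only meta to a large group. Because the earlier step was a 3.8-fold lower number from compound 1 to compound 2 (0.59 log units; beyond the scatter), a lower number is expected for compound 4, though the step from compound 3 to compound 4 is estimated smaller, a 2.0-fold lower number from compound 3 to compound 4 (0.30 log units; within the scatter), since the place is not identical. The expected value for compound 4 is 300 nM, with a likely range from 120 nM to 800 nM.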

Compound 4, half-maximal inhibitory concentration: 90 nM
For compound 4 the middle estimate is 3.3-fold (0.52 log units) above the measured one, and the stated range ends above it.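

In this assay, putting fluoro in place of methyl on an aromatic carbon gave a 6.7-fold lower number from compound 3 to compound 4 (0.82 log units; beyond the scatter), so the number fell on this core as it did on the core of compound 1. The two steps point the same way and cannot be told apart in size: the same change on two cores in this assay, a 3.8-fold lower number (0.59 log units; beyond the scatter) from compound 1 to compound 2 and a 6.7-fold lower number (0.82 log units; beyond the scatter) from compound 3 to compound 4, 1.7-fold (0.24 log units) apart, within the scatter of two such steps This shows the change carrying over between these two cores, although its place on the molecule differs between the pairs; it does not show that the change would carry over to any other core, nor why the number falls.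

The compounds shown leave open how chloro, methoxy or an amine would behave at the same aromatic carbon. They also leave open whether fluoro would lower the number at other places.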